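The source may report more compounds than this note shows. Statements on the series, on what has been measured and on what is new or still open speak of the compounds shown alone.

Measured compounds:
compound 1 `COc1ccccc1N1CCn2c1n[nH]c(=O)c2=O`: 26%
compound 2 `Cc1ccc(N2CCN/C2=N\N)cc1`: 0%
compound 3 `COc1ccc(N2CCn3c2n[nH]c(=O)c3=O)cc1`: 0%

These numbers come from an ADME assay on Vero cells (Chlorocebus sabaeus) for cytotoxicity, with a stated time of 72 h, tested at 10 ug/mL; on this read-out higher numbers stand for a stronger effect at the one concentration tested and lower numbers for a weaker effect. Compound 3 stands level with compound 2 at the digits shown; together they give the lowest of the three readings, while compound 1 reads higher by a gap that lies beyond the usual scatter. Compound 4 `Cc1ccc(N2CCn3c2n[nH]c(=O)c3=O)cc1` has not yet been measured. Its change from compound 3 is methyl in place of methoxy on an aromatic carbon. Compound 2 also carries a methyl group, on a different core, and in this assay compound 2 gives 0%. The step from compound 3 to compound 4 is therefore expected to be small, a number 5 percentage points higher from compound 3 to compound 4 (within the scatter), within the scatter rather than a real change. Compound 4 is estimated at 5%, with a range from 0% to 20%.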

Compound 4, a percentage reported as inhibition, at one concentration (the size of the read-out at that concentration, not a potency): 0%
Compound 4: the middle estimate sits 5 percentage points above what was measured, and the stated range covers the measured number.
By their numbers in this assay, from the lowest: compounds 2, 3 and 4 (each within the scatter of the next); then compound 1.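

In this assay, putting methyl in place of methoxy on an aromatic carbon, para to a large group, gives no change at the digits printed from compound 3 to compound 4 (within the scatter) on the shared core. At this position, then, the two groups cannot be told apart at the one concentration tested, and losing the oxygen of methoxy leaves the reading unmoved. Nothing measured here offers an explanation for this result. Still open, from the compounds shown here alone, is whether a different group at this position, such as an amine or a carboxylic acid, would give a reading different from that of compound 4. A single concentration also leaves open how these compounds would behave at higher doses.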